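Trifluoroacetyl piperidine amide in the pyrimidine ether series

The source may hold more compounds than are shown below. What is called first, only, known or untested is meant among the compounds shown, and "the series" means these compounds.

Measured compounds:
compound 1 `Cc1nc(S(C)(=O)=O)ccc1Oc1ncnc(OC2CCN(C(=O)OC3CCC3)CC2)c1F` gives 81% in a functional assay on isolated protein for inhibition of Glucose-dependent insulinotropic receptor (Rattus norvegicus), read by HTRF and cAMP accumulation; a lower number here means a smaller maximal response, a higher number a larger maximal response
compound 2 `Cc1nc(S(C)(=O)=O)ccc1Oc1ncnc(OC2CCN(C(=O)SC(C)(C)C)CC2)c1F` gives 76% in this assay
compound 3 `Cc1nc(S(C)(=O)=O)ccc1Oc1ncnc(OC2CCN(C(=S)OC3(C)CC3)CC2)c1F` gives 49% in this assay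

Compound 3 stands lowest of the three, with the gap a number 32 percentage points lower from compound 1 to compound 3 (beyond the scatter) and the gap a number 27 percentage points lower from compound 2 to compound 3 (beyond the scatter), both beyond the scatter, while a number 5 percentage points lower from compound 1 to compound 2 (within the scatter) lies within it.

Compound 4 `Cc1nc(S(C)(=O)=O)ccc1Oc1ncnc(OC2CCN(C(=O)C(F)(F)F)CC2)c1F` differs from compound 3 by a group of 6 heavy atoms (2 carbon, 1 oxygen, 3 fluorine; no ring) in place of a group of 7 heavy atoms (5 carbon, 1 oxygen, 1 sulfur; one three-membered non-aromatic ring of carbon only), on an amine nitrogen in a ring. Among the measured compounds shown here, no measured step covers this exchange. The two steps that reach compound 3 both show a fall when its thiocarbonyl group enters; compound 4 instead carries a (trifluoromethyl)carbonyl, a carbonyl as in compounds 1 and 2. A rise back toward those two is therefore expected in this assay, estimated as a number 21 percentage points higher from compound 3 to compound 4 (beyond the scatter). Compound 4 is expected to give 70%, within 50% to 88%.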

Compound 4, largest response reached (reported as efficacy), in percent of the reference or control that the assay uses: 76%
Compound 4: middle estimate off by 6 percentage points, on the low side; the range from low to high includes it.
By their numbers in this assay, from the lowest: compound 3; then compounds 2, 4 and 1 (each within the scatter of the next).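

On the amine nitrogen in a ring, trifluoromethyl on the carbonyl carbon reads level with the two earlier carbonyl groups in this assay (no change at the digits printed from compound 2 to compound 4 (within the scatter); a number 5 percentage points lower from compound 1 to compound 4 (within the scatter)), so neither the sulfur or oxygen link nor the tert-butyl or cyclobutyl carbons are needed there for this response. The step from the thiocarbonyl (a number 27 percentage points higher from compound 3 to compound 4 (beyond the scatter)) changes the double-bonded atom and the three-membered ring together, leaving their shares unseparated. No measurement bears on the reason.

Open, from the compounds shown here alone, are an amine or a longer chain on the carbonyl carbon, and a plain carbonyl carrying the three-membered ring of compound 3.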